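Triazole substituent swap on the butenolide series

The source may hold more compounds than are shown below. What is called first, only, known or untested is meant among the compounds shown, and "the series" means these compounds.

Compound 1 `O=C1O/C(=C\Cn2cc(Cc3ccccc3)nn2)C(OCc2ccccc2)=C1OCc1ccccc1` is the parent of this set. In a functional assay on HCT-116 cells (Homo sapiens) for antiproliferative activity, read by MTT assay, with a stated time of 24 h (a higher number here means a weaker inhibitor, a lower number a stronger inhibitor), compound 1 gives 83100 nM. Compound 2 `O=C1NC(O)(CCn2cc(-c3ccccc3)nn2)C(OCc2ccccc2)=C1OCc1ccccc1` gives 53400 nM in this assay, and compound 1 and compound 2 sit within the scatter of each other. Compound 3 `CC(C)(C)c1ccc(-c2cn(CCC3(O)NC(=O)C(OCc4ccccc4)=C3OCc3ccccc3)nn2)cc1` reaches only the limit of this assay, > 100000 nM. For the measured compounds named here, the one measured step, an at least 1.8-fold higher number from compound 2 to compound 3 (0.27 log units; that floor lies within the scatter), is a limit-bound change at the limit of > 100000 nM in this assay, at which 1 of the 3 values shown sits, and concerns a different group than the one altered here. Compound 4 `O=C1O/C(=C\Cn2cc(C3=CCCCC3)nn2)C(OCc2ccccc2)=C1OCc1ccccc1` differs from compound 1 by cyclohex-1-en-1-yl in place of benzyl on an aromatic carbon. Going by the values given here, no measured step tracks this swap, so no shift beyond the scatter is expected, a 1.0-fold higher number from compound 1 to compound 4 (0.01 log units; within the scatter). Compound 4 is therefore estimated at 85000 nM, between 40000 nM and 180000 nM.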

Compound 4, half-maximal inhibitory concentration: > 100000 nM
Compound 4 ended at the assay's limit; the forecaster's own chance of this, stated with the estimate: 30%; middle value at least 1.1-fold (0.07 log units) from the limit.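

For the compounds shown here, the first measured step at this position in this assay is an at least 1.2-fold higher number from compound 1 to compound 4 (0.08 log units; that floor lies within the scatter). Compound 4 sits at a limit of the assay, not at a number, so the size of this change stays unread and no loss of activity beyond the scatter is established. With this swap, the set gathers further at the top of the readable range: the limit of > 100000 nM in this assay, at which 2 of the 4 values shown sit.

Going by these compounds, whether compound 4 truly differs from compound 1 stays open. So does the effect of an amine, a carboxylic acid or a longer alkyl chain on this carbon.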